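Replacing the (4-nitrophenyl)carbonyl group of compound 3

This account rests on a few compounds, and the source may have more. Where it says the series, first, only, none or still open, it means among the compounds named here.

Three compounds share one core and differ only in the group on a saturated chain carbon bound to a double-bonded ring carbon. In a functional assay on HL-60 cells (Homo sapiens) for antiproliferative activity, read by MTT assay, with a stated time of 48 h (on this read-out higher numbers stand for weaker inhibition and lower numbers for stronger inhibition), compound 1 `CC(C)=CCC[C@]1(C)/C=C/[C@@H](OC(=O)C=C(C)C)[C@](C)(O)/C=C/C(=O)/C(CCl)=C\C1` gives 160 nM, and compound 2 `CC(C)=CCC[C@]1(C)/C=C/[C@@H](OC(=O)C=C(C)C)[C@](C)(O)/C=C/C(=O)/C(CN(C)C)=C\C1` gives 140 nM. Between them lies a 1.1-fold lower number from compound 1 to compound 2 (0.06 log units; within the scatter), so chloro and dimethylamino cannot be told apart here. Compound 3 `CC(C)=CCC[C@]1(C)/C=C/[C@@H](OC(=O)C=C(C)C)[C@](C)(O)/C=C/C(=O)/C(COC(=O)c2ccc([N+](=O)[O-])cc2)=C\C1`, which carries ((4-nitrophenyl)carbonyl)oxy, gives 830 nM, the highest number of the three and so the weakest inhibition. It stands clearly apart from the other two, with a 5.2-fold higher number from compound 1 to compound 3 (0.71 log units; beyond the scatter) and a 5.9-fold higher number from compound 2 to compound 3 (0.77 log units; beyond the scatter).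

Compound 4 `CSC(=S)OC/C1=C/C[C@](C)(CCC=C(C)C)/C=C/[C@@H](OC(=O)C=C(C)C)[C@](C)(O)/C=C/C1=O` changes compound 3 in one place: a group of 4 heavy atoms (2 carbon, 2 sulfur; no ring) in place of a group of 11 heavy atoms (7 carbon, 1 nitrogen, 3 oxygen; one six-membered aromatic ring of carbon only), on an oxygen on a saturated carbon. The (4-nitrophenyl)carbonyl leaves, and the group that enters has no common name. Among the measured compounds shown here, no measured step makes this exact swap, so the guide is indirect. For the measured compounds named here, the two modest steps above are the only ones beyond the scatter, and both lead to compound 3, the one compound carrying (4-nitrophenyl)carbonyl. Compound 4 loses that group, so a modest move back towards stronger inhibition is expected, though this rests on very few data. The expected size is a 2.8-fold lower number from compound 3 to compound 4 (0.44 log units; beyond the scatter) in this assay. Compound 4 is estimated at 300 nM, with an expected range of 110 nM to 800 nM.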

Compound 4, half-maximal inhibitory concentration: 180 nM
Compound 4: the middle estimate sits 1.7-fold (0.22 log units) above what was measured, and the stated range covers the measured number.
By their numbers in this assay, from the lowest: compounds 2, 1 and 4 (each within the scatter of the next); then compound 3.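

In this assay, keeping the oxygen on the saturated carbon and changing only what it carries gives a 4.6-fold lower number from compound 3 to compound 4 (0.66 log units; beyond the scatter), so having an oxygen at this point does not by itself bring the weaker inhibition seen with compound 3. The new group also joins the earlier pair, with a 1.3-fold higher number from compound 2 to compound 4 (0.11 log units; within the scatter) and a 1.1-fold higher number from compound 1 to compound 4 (0.05 log units; within the scatter), so chloro, dimethylamino and the sulfur-bearing group of compound 4 cannot be told apart here, and compound 3 alone stands apart among the four. Nothing available explains this difference between compound 3 and the others.

Still open, from the compounds shown here alone, is whether the weaker inhibition of compound 3 follows its nitro group, its aromatic ring or simply the larger size of its group, and a benzoyl group without the nitro, or a small acetyl group on the same oxygen, would help separate these. A free hydroxyl or a carboxylic acid on the same chain carbon would further test how widely this position accepts change.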